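The source may hold more compounds than are shown below. What is called first, only, known or untested is meant among the compounds shown, and "the series" means these compounds.

Compound 3 `COc1ccc(Cn2c(=O)nc(NCCNC(=N)N)n(Cc3ccc(F)cc3)c2=O)cc1` carries the highest number of the three compounds measured in a functional assay on the whole organism (strain C57Bl/6) for inhibition, with Mus musculus as the target, with a stated time of 180 min, at 48 degrees C (on this read-out lower numbers stand for an effect already at smaller amounts and higher numbers for an effect only at larger amounts of compound), with compound 3 giving 0.036 nM. Compound 1 `COc1ccc(Cn2c(=O)nc(NCCNC(=N)N)n(Cc3ccc(C)cc3)c2=O)cc1` gives 0.0045 nM, and compound 2 `Cc1ccc(Cn2c(=O)nc(NCCNC(=N)N)n(Cc3ccc(Cl)c(Cl)c3)c2=O)cc1` gives 0.0051 nM, two values within the scatter of each other. Compound 4 `COc1ccc(Cn2c(=O)nc(NCCNC(=N)N)n(Cc3ccc(Cl)c(Cl)c3)c2=O)cc1` has not yet been measured; it differs from compound 3 in one place: 3,4-dichlorophenyl in place of 4-fluorophenyl on a saturated chain carbon bound to an aromatic nitrogen. Within the data shown here, one measured step bears on this change: an 8.0-fold higher number from compound 1 to compound 3 (0.90 log units; beyond the scatter), so the fluoro variant sits well above the methyl variant. Compound 2 carries the same 3,4-dichlorophenyl as compound 4 and sits close to compound 1. A step of about that size in the opposite direction is therefore expected, a 6.0-fold lower number from compound 3 to compound 4 (0.78 log units; beyond the scatter), in this assay. Compound 4 is estimated at 0.006 nM, in the range 0.002 nM to 0.02 nM.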

Compound 4, half-maximal effective concentration: 0.0045 nM
Estimate against measurement, compound 4: 1.3-fold (0.12 log units) above; the measured number falls inside the stated range.
By their numbers in this assay, from the lowest: compounds 1, 4 and 2 (each within the scatter of the next); then compound 3.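

In this assay, 3,4-dichlorophenyl in place of 4-fluorophenyl gives an 8.0-fold lower number from compound 3 to compound 4 (0.90 log units; beyond the scatter), at the saturated chain carbon bound to an aromatic nitrogen. With 3,4-dichlorophenyl in place of 4-methylphenyl there is no change at the digits printed from compound 1 to compound 4 (within the scatter), and methoxy in place of methyl on the aromatic carbon gives a 1.1-fold lower number from compound 2 to compound 4 (0.05 log units; within the scatter), so among these compounds only compound 3, with its 4-fluorophenyl, stands apart. Nothing measured here explains that difference.

From the compounds shown here alone, it remains open whether 4-chlorophenyl would match 3,4-dichlorophenyl or 4-fluorophenyl at this place. Going by these compounds, how an unsubstituted phenyl or a pyridine ring would behave there is also open.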